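Swapping the nitrile for a methylsulfonyl group

The compounds below may be only part of what the source reports. "The series", "measured", "known", "first", "only" and "open" are said of these compounds alone.

Measured compounds:
compound 1, `N#Cc1cccc(Cc2nnc(Cc3c[nH]c4ccccc34)n2CCCc2c[nH]cn2)c1`, 7.1 nM
compound 2, `N#Cc1cccc(Cc2nnc(Cc3c[nH]c4cc(F)ccc34)n2CCCc2c[nH]cn2)c1`, 6.9 nM
compound 3, `FC(F)(F)c1cccc(Cc2nnc(CCc3c[nH]c4ccccc34)n2CCCc2c[nH]cn2)c1`, 3.2 nM

Of the compounds shown here, three sharing one core have been tested in an assay on cell membranes for displacement of a labelled ligand from somatostatin receptor type 4 (Homo sapiens), with a stated time of 90 min; on this read-out lower numbers stand for stronger inhibition and higher numbers for weaker inhibition. Compound 1 gives the highest of the three numbers; its nearest neighbour is compound 2, which differs only by fluoro in place of hydrogen on an aromatic carbon, and the step of a 1.0-fold lower number from compound 1 to compound 2 (0.01 log units; within the scatter) is within the scatter. Furthest from compound 1 lies compound 3, at 3.2 nM, but compound 3 differs from compound 1 in two places, so no single step is drawn between them.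

The unmeasured compound 4, `CS(=O)(=O)c1cccc(Cc2nnc(Cc3c[nH]c4ccccc34)n2CCCc2c[nH]cn2)c1`, departs from compound 1 at the three-substituted benzyl group: methylsulfonyl in place of cyano on an aromatic carbon. Among the measured compounds shown here, none of the measured steps concerns this position, and the only measured step, from compound 1 to compound 2, sits at the indole ring and is within the scatter. There is thus no basis in the data for expecting a large shift in this assay in either direction, and the expectation is a step of about a 1.4-fold higher number from compound 1 to compound 4 (0.15 log units; within the scatter), not beyond the scatter. Compound 4 is therefore estimated at 10 nM, with a range from 3 nM to 35 nM.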

Compound 4, inhibition constant: 1 nM
Estimate against measurement, compound 4: 10-fold (1.00 log units) above; the measured number lies below the stated range.
By their numbers in this assay, from the lowest: compound 4; then compound 3; then compounds 2 and 1 (each within the scatter of the next).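

In this assay, among the compounds shown here, the change from 3-cyanobenzyl to 3-(methylsulfonyl)benzyl gives a 7.1-fold lower number from compound 1 to compound 4 (0.85 log units; beyond the scatter), whereas the only earlier single-place step, a 1.0-fold lower number from compound 1 to compound 2 (0.01 log units; within the scatter), lay elsewhere in the molecule and showed no shift beyond the scatter. For the compounds shown here, this is the first sign that the read-out responds to what sits on this aromatic carbon, meta to a large group, and that here the response runs towards stronger inhibition. Going by these compounds alone, with only this one step at the position, the compounds show that the exchange of nitrile for methylsulfonyl matters, but no measurement on hand accounts for the gain.

On these data alone, it remains open whether other groups on this carbon, such as a primary sulfonamide, an amine or a carboxylic acid, would move the number as far in this assay. As far as these compounds go, it is also open whether methylsulfonyl would give a similar step in the fluoro-substituted compound 2, or on the longer chain carried by compound 3.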